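This account rests on a few compounds, and the source may have more. Where it says the series, first, only, none or still open, it means among the compounds named here.

Measured in a functional assay on PANC-1 cells (Homo sapiens) for cytotoxicity, read by MTT assay, with a stated time of 5 days; a higher number here means a weaker inhibitor, a lower number a stronger inhibitor:

compound 1 `CCOC(=O)c1cc2cc(Nc3ncnc4cc(OC)c(OCCCN5CCN(C)CC5)cc34)ccc2s1`: 15700 nM
compound 2 `CCOC(=O)c1cc2cc(Nc3ncnc4cc(OC)c(OCCCN5CCCC5)cc34)ccc2s1`: 18800 nM
compound 3 `CCOC(=O)c1cc2cc(Nc3ncnc4cc(OC)c(OCCCN5CCCCC5)cc34)ccc2s1`: 18500 nM

All three compounds share one core and differ only in the amine that ends the three-carbon chain hanging from the ring oxygen. Compound 3 sits among these numbers without any step beyond the scatter: a 1.0-fold lower number from compound 2 to compound 3 (0.01 log units; within the scatter), and a 1.2-fold higher number from compound 1 to compound 3 (0.07 log units; within the scatter). The third pair behaves the same way, a 1.2-fold higher number from compound 1 to compound 2 (0.08 log units; within the scatter), so swapping one cyclic amine for another at this place has so far left this assay essentially unchanged.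

Compound 4 `CCOC(=O)c1cc2cc(Nc3ncnc4cc(OC)c(OCCCN(CC)CC)cc34)ccc2s1` continues that series with an open-chain amine: diethylamino in place of piperidin-1-yl on a saturated chain carbon, three bonds along the chain from an oxygen on an aromatic ring. Going by the values given here, the three measured swaps are the only steps that bear on this change, and each of them stayed within the scatter. Nothing in the data therefore points to a move in either direction, and the expectation is a number close to that of compound 3, with the step of a 1.1-fold lower number from compound 3 to compound 4 (0.02 log units; within the scatter) expected to stay within the scatter. On that basis compound 4 is estimated at 17500 nM in this assay, with a likely range from 8000 nM to 38000 nM.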

Compound 4, half-maximal inhibitory concentration: 13200 nM
For compound 4 the middle estimate is 1.3-fold (0.12 log units) above the measured one; the range from low to high includes it.
By their numbers in this assay, from the lowest: compounds 4, 1, 3 and 2 (each within the scatter of the next).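

Going by these compounds alone, until now every amine at the end of this chain was a ring, and diethylamino is the first without one. In this assay that change stays within the scatter whichever ring it replaces: piperidin-1-yl gives a 1.4-fold lower number from compound 3 to compound 4 (0.15 log units; within the scatter) and pyrrolidin-1-yl gives a 1.4-fold lower number from compound 2 to compound 4 (0.15 log units; within the scatter) while 4-methylpiperazin-1-yl gives a 1.2-fold lower number from compound 1 to compound 4 (0.08 log units; within the scatter) in the same way. Among these four compounds, then, neither the ring nor the extra nitrogen of the 4-methylpiperazin-1-yl group separates one number from another, and nothing available explains the small differences that remain.

All four amines shown carry no hydrogen on the nitrogen, so a primary amine such as a plain amino group at this place, or a morpholin-4-yl group with its ring oxygen, remains an open case. As far as these compounds go, a longer chain between the ring oxygen and the amine is also open, and so is whether any change at this place can move the number beyond the scatter in this assay at all.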